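Aryl urea series: from compound 2 to compound 4

The source may report more compounds than this note shows. Statements on the series, on what has been measured and on what is new or still open speak of the compounds shown alone.

Compound 2 `Cc1cccc(NC(=O)N[C@H]2CC[C@H](Oc3ccc(F)cc3)CC2)c1` is one of three ureas on a shared core with numbers in a functional assay on CRL2813 cells (Homo sapiens) for cytotoxicity, read by sulforhodamine B assay, with a stated time of 5 days; on this read-out lower numbers stand for stronger inhibition and higher numbers for weaker inhibition. Compound 2 gives 14400 nM. Compound 3 `COC(=O)c1cccc(NC(=O)N[C@H]2CC[C@H](Oc3ccc(F)cc3)CC2)c1` gives 9200 nM. Compound 1 `CSc1ccccc1NC(=O)N[C@H]1CC[C@H](Oc2ccc(F)cc2)CC1` reaches only a limit of the assay, recorded as > 20000 nM. Of the two numbers shown, compound 2 has the larger, yet the gap a 1.6-fold lower number from compound 2 to compound 3 (0.19 log units; within the scatter) is within the scatter, so no order between compound 2 and compound 3 is claimed. The step of an at least 1.3-fold lower number from compound 1 to compound 2 (0.14 log units; that floor lies within the scatter) rests on a limit of > 20000 nM in this assay, at which 1 of the 3 values shown sits, and likewise does not exceed the scatter.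

Compound 4 `O=C(Nc1ccccc1F)N[C@H]1CC[C@H](Oc2ccc(F)cc2)CC1` differs from compound 2 by 2-fluorophenyl in place of 3-methylphenyl on an amide-type nitrogen. The two measured steps that vary the aryl group on the amide-type nitrogen, an at least 1.3-fold lower number from compound 1 to compound 2 (0.14 log units; that floor lies within the scatter) and a 1.6-fold lower number from compound 2 to compound 3 (0.19 log units; within the scatter), both stayed within the scatter or at the limit, so for the change to compound 4 no step beyond the scatter is expected in this assay, in either direction. Compound 4 is therefore expected near 15000 nM, with a range of 7000 nM to 30000 nM. The expected step is a 1.0-fold higher number from compound 2 to compound 4 (0.02 log units; within the scatter), an estimate only.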

Compound 4, half-maximal inhibitory concentration: 17500 nM
The estimate for compound 4 lay 1.2-fold (0.07 log units) below the measured number; the range from low to high includes it.
By their numbers in this assay, from the lowest: compounds 3, 2 and 4 (each within the scatter of the next). At a limit, above all of these: compound 1.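

In this assay the series now includes a fluorine-bearing aryl group on the amide-type nitrogen: 2-fluorophenyl in place of 3-methylphenyl gives a 1.2-fold higher number from compound 2 to compound 4 (0.08 log units; within the scatter), so this swap, with the same heavy-atom count in both groups, also produces no step beyond the scatter. The second new comparison, fluoro in place of methylsulfanyl on an aromatic carbon, gives an at least 1.1-fold lower number from compound 1 to compound 4 (0.05 log units; that floor lies within the scatter), which adds a further aryl change at this position but no resolved difference. Compound 1 stands at a limit of the assay, so that comparison provides only a floor and not a measured size: the limit of > 20000 nM in this assay, at which 1 of the 4 values shown sits.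

Open, from the compounds shown here alone, is whether any aryl substituent at this position can move the number beyond the scatter, for example an amine, a carboxylic acid or a longer alkyl chain in place of the methyl of compound 2. Also open is how much the shared core contributes to the cytotoxicity read-out, as it stays the same in every compound shown.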